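The compounds below may be only part of what the source reports. "The series", "measured", "known", "first", "only" and "open" are said of these compounds alone.

The compounds measured so far, with their results in a functional assay for inhibition of sodium/hydrogen exchanger (Oryctolagus cuniculus); on this read-out lower numbers stand for stronger inhibition and higher numbers for weaker inhibition:
compound 1 `CS(=O)(=O)c1cc(C(=O)N=C(N)N)ccc1-n1cccn1`, 160 nM;
compound 2 `CS(=O)(=O)c1cc(C(=O)N=C(N)N)ccc1Oc1cccnc1`, 76 nM;
compound 3 `CS(=O)(=O)c1cc(C(=O)N=C(N)N)ccc1N1CCCCC1`, 130 nM.

Compound 3 stands second highest of the three numbers, yet a 1.2-fold lower number from compound 1 to compound 3 (0.09 log units; within the scatter) and a 1.7-fold higher number from compound 2 to compound 3 (0.23 log units; within the scatter) both lie within the scatter; only a 2.1-fold lower number from compound 1 to compound 2 (0.32 log units; beyond the scatter) reaches beyond it. Compound 4 `CS(=O)(=O)c1cc(C(=O)N=C(N)N)ccc1N1CCC(N)CC1` differs from compound 3 in one place: amino in place of hydrogen on a saturated ring carbon. Within the data shown here, none of the measured steps touches that saturated ring; each of them exchanges the whole group on the aromatic carbon, and all were modest or within the scatter. With nothing bearing directly on this change, no step beyond the scatter is expected. Compound 4 is estimated at 120 nM in this assay, with a range from 40 nM to 360 nM. The expected step is a 1.1-fold lower number from compound 3 to compound 4 (0.03 log units; within the scatter).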

Compound 4, half-maximal inhibitory concentration: 160 nM
Compound 4: the middle estimate sits 1.3-fold (0.12 log units) below what was measured; the range from low to high includes it.
By their numbers in this assay, from the lowest: compounds 2, 3, 1 and 4 (each within the scatter of the next, the first and the last beyond it).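

The saturated ring accepts a new group at this position: a 1.2-fold higher number from compound 3 to compound 4 (0.09 log units; within the scatter) in this assay means that amino, three ring bonds from the ring nitrogen, makes no readable difference. Changing the whole group gives no change at the digits printed from compound 1 to compound 4 (within the scatter) and a 2.1-fold higher number from compound 2 to compound 4 (0.32 log units; beyond the scatter), and only the second of these clears the scatter, modestly. Nothing available here explains these results.

From the compounds shown here alone, whether a carboxylic acid on the same ring carbon would also stay within the scatter remains open. So does the effect of a longer chain ending in an amine.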